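Fluoromethyl on the branched chain of compound 3

A few compounds are considered here, and "the series" means these few. Any claim that something is new, unique, unknown or untested is made for them only; others in the source may bear on it.

In a functional assay on HeLa cells (Homo sapiens) for cytotoxicity, read by WST assay, with a stated time of 48 h (a higher number here means a weaker inhibitor, a lower number a stronger inhibitor), compound 3 `COc1cc(C(c2ccc(O)c(OC)c2)[C@@H](C)C(C)C)ccc1O` gives 19000 nM, and compound 1 `COc1cc(C(c2ccc(O)c(OC)c2)[C@H](C)C(C)C)ccc1O` gives 16000 nM. These two share the same atoms and bonds, and a 1.2-fold higher number from compound 1 to compound 3 (0.07 log units; within the scatter) lies within the scatter. Compound 2 `COc1cc(C(c2ccc(O)c(OC)c2)[C@H](C)[C@H](C)CO)ccc1O` reports only a limit, > 100000 nM.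

The change to compound 4 `COc1cc(C(c2ccc(O)c(OC)c2)[C@H](CF)C(C)C)ccc1O` is 1-(fluoromethyl)-2-methylpropyl in place of 1,2-dimethylpropyl on a saturated chain carbon bound to two aromatic carbons.

Among the compounds with values here, the closest precedent is the hydroxy change in compound 2, with an at least 6.2-fold higher number from compound 1 to compound 2 (0.79 log units; beyond the scatter). Its counterpart is an at least 5.2-fold lower number from compound 2 to compound 3 (0.72 log units; beyond the scatter). Both steps go beyond the scatter, but both rest on a limit and neither involves fluorine, so they are only weak guides. Within the data shown here, no measured step here tests fluorine directly. Little change is therefore expected, with some risk towards a higher number, and the expected step is a 1.2-fold higher number from compound 3 to compound 4 (0.06 log units; within the scatter). The estimated value for compound 4 is 22000 nM, with an expected range of 9000 nM to 60000 nM.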

Compound 4, half-maximal inhibitory concentration: 19000 nM
Beside the measured number, compound 4's estimate is 1.2-fold (0.06 log units) above it; the range from low to high includes it.
By their numbers in this assay, from the lowest: compounds 1, 3 and 4 (each within the scatter of the next). At a limit, above all of these: compound 2.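

In this assay, within the data shown here, fluoro on this saturated chain carbon gives the first direct reading for fluorine: no change at the digits printed from compound 3 to compound 4 (within the scatter) and a 1.2-fold higher number from compound 1 to compound 4 (0.07 log units; within the scatter). Both methyl compounds serve equally as references for this change: the fact that compounds 1 and 3 differ only in the configuration as drawn. Unlike the hydroxy-bearing chain, the fluoromethyl chain stays in the range of those references, with an at least 5.2-fold lower number from compound 2 to compound 4 (0.72 log units; beyond the scatter), a step that rests on a limit: the limit of > 100000 nM in this assay, at which 1 of the 4 values shown sits.

Going by these compounds, whether difluoromethyl, an aminomethyl group or a carboxylic acid on this chain would hold the number stays open. On these data alone, how the opposite drawn configuration of the fluoromethyl chain would read also stays open.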